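Trifluoromethoxy for dimethoxy on the sulfonyl aryl group

The source may hold more compounds than are shown below. What is called first, only, known or untested is meant among the compounds shown, and "the series" means these compounds.

Two members of this series share the same core and differ only in the aryl group carried on the sulfonyl sulfur. Compound 1 `CN(c1ccc2[nH]c(-c3n[nH]c4ccccc34)cc2n1)S(=O)(=O)c1ccccc1` bears a plain phenyl there, and in a functional assay on HCT-116 cells (Homo sapiens) for antiproliferative activity, read by MTT assay, with a stated time of 72 h (on this read-out higher numbers stand for weaker inhibition and lower numbers for stronger inhibition), compound 1 gives 6740 nM. Compound 2 `COc1ccc(OC)c(S(=O)(=O)N(C)c2ccc3[nH]c(-c4n[nH]c5ccccc45)cc3n2)c1` carries a 2,5-dimethoxyphenyl instead, and in this assay compound 2 gives 8400 nM. The step of a 1.2-fold higher number from compound 1 to compound 2 (0.10 log units; within the scatter) is within the scatter, so the two measured compounds cannot be ordered against each other. Compound 2 holds the highest of the two numbers seen so far, with compound 1 its nearest neighbour and within the scatter of it.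

Compound 3 `CN(c1ccc2[nH]c(-c3n[nH]c4ccccc34)cc2n1)S(=O)(=O)c1ccc(OC(F)(F)F)cc1` has not yet been measured. It differs from compound 2 by 4-(trifluoromethoxy)phenyl in place of 2,5-dimethoxyphenyl on a sulfonyl sulfur. Among the compounds with values here, the only step that bears on this change is the one from compound 1 to compound 2, which was within the scatter, so an aryl swap at this sulfonyl position has so far left this assay unmoved beyond the scatter. Compound 3 is therefore expected to show a step of about a 1.2-fold lower number from compound 2 to compound 3 (0.08 log units; within the scatter), no larger than the scatter. The estimate for compound 3 in this assay is 7000 nM, with a range from 3000 nM to 16000 nM.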

Compound 3, half-maximal inhibitory concentration: 6040 nM
Beside the measured number, compound 3's estimate is 1.2-fold (0.06 log units) above it; measured number inside the range.
By their numbers in this assay, from the lowest: compounds 3, 1 and 2 (each within the scatter of the next).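

In this assay the swap of 2,5-dimethoxyphenyl for 4-(trifluoromethoxy)phenyl on a sulfonyl sulfur gives a small step (a 1.4-fold lower number from compound 2 to compound 3 (0.14 log units; within the scatter)), and placing trifluoromethoxy on an aromatic carbon in place of hydrogen gives another (a 1.1-fold lower number from compound 1 to compound 3 (0.05 log units; within the scatter)). The earlier compounds shown here offered a single comparison, between phenyl and 2,5-dimethoxyphenyl, whereas the position now has three aryl groups, including one that carries fluorine, and every step among them lies within the scatter, so none of the three can be ordered against the others on this read-out. No supporting measurement is available to explain why these aryl groups leave the number within the scatter.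

From the compounds shown here alone, it remains open whether an amine or a carboxylic acid on the sulfonyl aryl group, or a longer alkyl chain in place of that aryl group on the sulfonyl sulfur, would produce a step beyond the scatter. Also open, going by these compounds, is whether a change to the shared core would move the number further than these aryl swaps, as all three compounds keep that core unchanged.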